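A few compounds are considered here, and "the series" means these few. Any claim that something is new, unique, unknown or untested is made for them only; others in the source may bear on it.

Of the compounds shown here, three sharing one core have been tested in a functional assay on HeLa cells (Homo sapiens) for antiproliferative activity, with a stated time of 24 h; a lower number here means a stronger inhibitor, a higher number a weaker inhibitor. Compound 1, `NC(=O)c1c(NC(=O)c2ccccc2Cl)sc2c1CCNC2`, gives 45000 nM. Compound 2, `NC(=O)c1c(NC(=O)c2ccccc2Cl)sc2c1CCN(Cc1ccccc1F)C2`, carries a 2-fluorobenzyl on the amine nitrogen in the ring, and in this assay compound 2 reaches only the limit > 50000 nM. Compound 3, `NC(=O)c1c(NC(=O)c2ccccc2Cl)sc2c1CCN(Cc1ccc(Cl)cc1Cl)C2`, carries a 2,4-dichlorobenzyl there instead, and compound 3 gives 21100 nM. Among the numbers shown, compound 3 stands lowest; compound 1 is the nearest, and the remaining value is a limit. The step of a 2.1-fold lower number from compound 1 to compound 3 (0.33 log units; beyond the scatter) is modest, an at least 2.3-fold lower number from compound 2 to compound 3 (0.37 log units; beyond the scatter) is at least modest, and an at least 1.1-fold higher number from compound 1 to compound 2 (0.04 log units; that floor lies within the scatter) has a floor that lies within the scatter.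

Compound 4, `NC(=O)c1c(NC(=O)c2ccccc2Cl)sc2c1CCN(C(=S)Nc1ccccc1Br)C2`, has not yet been measured. Compared with compound 3 it has a group of 10 heavy atoms (7 carbon, 1 nitrogen, 1 sulfur, 1 bromine; one six-membered aromatic ring of carbon only) in place of a group of 9 heavy atoms (7 carbon, 2 chlorine; one six-membered aromatic ring of carbon only), on an amine nitrogen in a ring; the entering group brings 1 hydrogen-bond donor, 1 hydrogen-bond acceptor and 1 double bond outside aromatic rings, where the leaving group brought none of these. The measured steps at this same amine nitrogen were modest or within the scatter, so at most a modest step is expected here, with no firm direction. Compound 4 is therefore expected to give about 25000 nM, between 8000 nM and 50000 nM. That estimate means a step of a 1.2-fold higher number from compound 3 to compound 4 (0.07 log units; within the scatter), expected rather than known.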

Compound 4, half-maximal inhibitory concentration: 24600 nM
Compound 4: the middle estimate sits 1.0-fold (0.01 log units) above what was measured, within the range that was stated.
By their numbers in this assay, from the lowest: compounds 3, 4 and 1 (each within the scatter of the next, the first and the last beyond it). At a limit, above all of these: compound 2.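

In this assay, the amine nitrogen in the ring now carries something other than a substituted benzyl: the entering group in compound 4 brings sulfur, bromine, a double bond outside aromatic rings, a hydrogen-bond donor and a hydrogen-bond acceptor, yet a 1.2-fold higher number from compound 3 to compound 4 (0.07 log units; within the scatter) shows no change that can be told from scatter. Set against the bare nitrogen, a 1.8-fold lower number from compound 1 to compound 4 (0.26 log units; within the scatter) also stays within the scatter, so compound 4 cannot be separated from compound 1 or from compound 3, even though those two differ from each other by a modest step. The comparison with compound 2 gives only a floor, and that floor lies within the scatter, an at least 2.0-fold lower number from compound 2 to compound 4 (0.30 log units; that floor lies within the scatter), because the reading for compound 2 is a limit and not a number: the limit of > 50000 nM in this assay, at which 1 of the 4 values shown sits.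

Among these compounds, no pair here changes the sulfur or the bromine alone, so a urea with oxygen in place of sulfur, or the same group with a plain phenyl ring, would be needed to show whether either atom matters. From the compounds shown here alone, it also remains open whether a quite different group on this nitrogen, such as a carboxylic acid or a longer chain ending in an amine, would move the reading well beyond the scatter.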